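A few compounds are considered here, and "the series" means these few. Any claim that something is new, unique, unknown or untested is made for them only; others in the source may bear on it.

Measured compounds and values:
- compound 1 `NCCCNCCCCNCCCNC(=O)[C@H](CC1CCCCC1)NC(=O)C1CCCCC1`: 2.19 nM
- compound 2 `NCCCNCCCCNCCCNC(=O)[C@H](CC1CCCCC1)NC(=O)CC1CC2CCC1C2`: 0.95 nM

In an assay on cells for antagonist activity at Neuronal acetylcholine receptor; alpha3/beta4 (Homo sapiens), read by two-electrode voltage clamp, with a stated time of 1 min (on this read-out lower numbers stand for stronger inhibition and higher numbers for weaker inhibition), compound 2 gives 0.95 nM, the lowest of the two numbers on hand; its nearest neighbour is compound 1, which in this assay gives 2.19 nM. For the measured compounds named here, the only measured step, a 2.3-fold lower number from compound 1 to compound 2 (0.36 log units; beyond the scatter), is a modest change from a six-membered non-aromatic carbon ring to a group of 8 heavy atoms with 2 five-membered non-aromatic rings on the carbonyl carbon.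

Compound 3 `NCCCNCCCCNCCCNC(=O)[C@H](CC1CCCCC1)NC(=O)c1ccccc1` is unmeasured. It differs from compound 2 by a group of 6 heavy atoms (6 carbon; one six-membered aromatic ring of carbon only) in place of a group of 8 heavy atoms (8 carbon; 2 five-membered non-aromatic rings of carbon only), on a carbonyl carbon: the phenyl enters where the bicyclic group leaves, the place being a carbonyl carbon whose other neighbour is an amide-type nitrogen. Going by the values given here, the one step that bears on this is a 2.3-fold lower number from compound 1 to compound 2 (0.36 log units; beyond the scatter), in which the group of 8 heavy atoms gave a modestly lower number than a six-membered ring at the same position. Returning to a six-membered ring, now aromatic, is therefore expected to give a modest step back toward the number for compound 1, of about a 2.1-fold higher number from compound 2 to compound 3 (0.32 log units; beyond the scatter), though the aromatic ring is not directly covered by any measured pair. For compound 3 in this assay the estimate is 2 nM, with a range from 0.9 nM to 4.5 nM.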

Compound 3, half-maximal inhibitory concentration: 0.37 nM
Estimate against measurement, compound 3: 5.4-fold (0.73 log units) above; the whole stated range lies above it.
By their numbers in this assay, from the lowest: compound 3; then compound 2; then compound 1.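

In this assay, for the compounds shown here, this position on the carbonyl carbon, whose other neighbour is an amide-type nitrogen, tolerates an aromatic ring and gives the lowest number so far: phenyl in place of the bicyclic group gives a 2.6-fold lower number from compound 2 to compound 3 (0.41 log units; beyond the scatter), and phenyl in place of cyclohexyl gives a 5.9-fold lower number from compound 1 to compound 3 (0.77 log units; beyond the scatter). The earlier step suggested that the larger group of 8 heavy atoms lowered the number, but the series does not follow group size, since the two groups of 6 heavy atoms give both the highest and the lowest numbers, and the aromatic ring accounts for the larger of the steps, though this rests on compound 3 alone. Nothing on hand explains the lower number for phenyl.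

The compounds shown leave open whether a second aromatic ring, such as pyridyl or naphthyl, or a phenyl carrying a methoxy group or a fluorine, would keep or lower the number of compound 3. They also leave open whether phenyl has the same effect when the cyclohexylmethyl side chain or the polyamine chain is replaced, for example by a benzyl side chain or a shorter chain.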